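A Nitro Group Takes the Place of Chlorine

This account rests on a few compounds, and the source may have more. Where it says the series, first, only, none or still open, it means among the compounds named here.

Of the compounds shown here, three with the same core have been measured; they differ only in the aryl group bound to the double-bonded chain carbon. Compound 1 `O=C1/C(=C\c2cccc(Br)c2)c2ccccc2N1c1c(Cl)cccc1Cl` carries 3-bromophenyl there, and in a functional assay on B16-F10 cells (Homo sapiens) for cytotoxicity against B16-F10 (Mus musculus), read by MTT assay, with a stated time of 72 h (on this read-out higher numbers stand for an effect only at larger amounts of compound and lower numbers for an effect already at smaller amounts), compound 1 gives 8 ug/mL. Compound 2 `O=C1/C(=C\c2ccccc2Cl)c2ccccc2N1c1c(Cl)cccc1Cl` carries 2-chlorophenyl, and in this assay compound 2 gives 39 ug/mL, the highest of the two plain numbers recorded. Going by the values given here, the only step between measured compounds is a 4.9-fold higher number from compound 1 to compound 2 (0.69 log units; beyond the scatter). Compound 3 `COc1ccc(/C=C2\C(=O)N(c3c(Cl)cccc3Cl)c3ccccc32)cc1OC` carries a dimethoxy-substituted phenyl. In this assay compound 3 reaches only a limit, > 100 ug/mL, so no number is known for it. Compound 3 thus sits at the limit of > 100 ug/mL in this assay, at which 1 of the 3 values shown sits.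

Compound 4 `O=C1/C(=C\c2ccccc2[N+](=O)[O-])c2ccccc2N1c1c(Cl)cccc1Cl` differs from compound 2 in one place: nitro in place of chloro on an aromatic carbon. Among the compounds with values here, no measured step exchanges chloro for nitro, so none bears directly on this change. Within the data shown here, the single measured step concerns a different exchange of the whole aryl group, and the limit for compound 3 gives no size at all. With no direct guide, the step of a 1.2-fold higher number from compound 2 to compound 4 (0.06 log units; within the scatter) is expected to stay within the usual scatter, leaning towards a somewhat higher number. Compound 4 is therefore expected to give about 45 ug/mL in this assay, within a range from 15 ug/mL to 100 ug/mL.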

Compound 4, concentration for half-maximal effect: > 100 ug/mL
Compound 4: only a limit was reported; the forecaster's own chance of this, stated with the estimate: 25%; middle value at least 2.2-fold (0.34 log units) away from the limit.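

In this assay compound 4 gives > 100 ug/mL, which is a limit and not a number, and it joins the compounds that rest there: the limit of > 100 ug/mL in this assay, at which 2 of the 4 values shown sit.

Even so, exchanging only chloro for nitro on this aromatic carbon gives an at least 2.5-fold higher number from compound 2 to compound 4 (0.40 log units; beyond the scatter), so a change of one group, with the rest of the molecule kept, is enough to move the number, something the earlier step, which exchanged one whole aryl group for another, could not show. Going by these compounds, the wider comparison, 2-nitrophenyl in place of 3-bromophenyl, gives an at least 12-fold higher number from compound 1 to compound 4 (1.09 log units; beyond the scatter), and how far this step really reaches stays unknown, as only one of its two ends is a number.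

On these data alone, it remains open whether 3-nitrophenyl would behave more like 3-bromophenyl or more like 2-nitrophenyl, which would help separate the effect of the group from the effect of where it sits. Also open, as far as these compounds go, is what an amine or a carboxylic acid would do on this aromatic carbon in place of chloro.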